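Ethyl in Place of Tert-Butyl on the Amide-Type Nitrogen

The compounds below may be only part of what the source reports. "The series", "measured", "known", "first", "only" and "open" are said of these compounds alone.

Of the compounds shown here, three sharing one core have been measured in a functional assay on WiDr cells (Homo sapiens) for inhibition; on this read-out lower numbers stand for stronger inhibition and higher numbers for weaker inhibition. Compound 1 `CC(C)(C)NC(=O)N1CC1C#N` carries a tert-butyl group on the amide-type nitrogen. In this assay compound 1 gives only a limit, > 300000 nM, and no number. Compound 2 `N#CC1CN1C(=O)Nc1ccccc1` differs at that nitrogen and gives 12000 nM in this assay. Compound 3 `N#CC1CN1C(=O)Nc1ccc(F)cc1` carries fluoro in place of hydrogen on an aromatic carbon and gives 9000 nM. Within the data shown here, the single step between measured compounds, a 1.3-fold lower number from compound 2 to compound 3 (0.12 log units; within the scatter), concerns that aromatic fluoro and does not bear on the change now considered, which is ethyl in place of tert-butyl on an amide-type nitrogen. Compound 4 `CCNC(=O)N1CC1C#N` carries ethyl on the amide-type nitrogen. Compound 1 sits at the limit of > 300000 nM in this assay, at which 1 of the 3 values shown sits. Among the measured compounds shown here, no measured step tells how one alkyl group compares with another on the amide-type nitrogen, so the expectation rests only on the weak showing of compound 1. Compound 4 is therefore expected to remain weak, with an estimated step of a number no higher from compound 1 to compound 4 (the limit leaves the size open) in this assay. The estimate for compound 4 is 300000 nM, between 60000 nM and 1500000 nM, with a fair chance that only a limit is again reported.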

Compound 4, half-maximal inhibitory concentration: 7000 nM
Estimate against measurement, compound 4: 43-fold (1.63 log units) above; measured number outside the range, below it.
By their numbers in this assay, from the lowest: compounds 4, 3 and 2 (each within the scatter of the next). At a limit, above all of these: compound 1.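

The result shows that an alkyl group on the amide-type nitrogen does not by itself rule out a measurable value, which the weak showing of the tert-butyl compound had left in doubt: in this assay, ethyl in place of tert-butyl gives an at least 42-fold lower number from compound 1 to compound 4 (1.63 log units; beyond the scatter). Until now, measurable values had come only from the compounds with an aromatic group at this nitrogen, but compound 4, at 7000 nM, now stands within the scatter of compound 3, at 9000 nM, so the aromatic ring is not required for a value in this range. The true size of the step stays open on one side, and the change shows only that the choice of alkyl group at this nitrogen matters, without giving a reason: the limit of > 300000 nM in this assay, at which 1 of the 4 values shown sits.

The compounds shown leave open where along the alkyl groups the loss sets in, since methyl, isopropyl and a longer chain such as n-butyl do not appear among them. They also leave open whether an amine or a carboxylic acid at the end of such a chain would be tolerated on the amide-type nitrogen.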